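Series notes: two measured ether amines, one pending

A few compounds are considered here, and "the series" means these few. Any claim that something is new, unique, unknown or untested is made for them only; others in the source may bear on it.

Measured so far:
compound 1 `O=c1cc(-c2ccccc2)oc2cccc(OCCCN3CCC(O)CC3)c12` gives 125 nM
compound 2 `CN(C)CCCCCCCCOc1ccc2oc(-c3ccccc3)cc(=O)c2c1` gives 227 nM

Both numbers come from an assay on isolated protein (Cavia porcellus) with Sigma non-opioid intracellular receptor 1 (Homo sapiens) as the target, read by radioligand binding; a higher number here means a weaker inhibitor, a lower number a stronger inhibitor. Compound 2 and compound 1 cannot be told apart on these two results; the gap between them lies within the scatter of repeated measurements, so neither is taken as the stronger or weaker of the pair. Going by the values given here, no step between measured compounds that differ in a single place is available, so no measured step guides what follows.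

Compound 3 `O=c1cc(-c2ccccc2)oc2ccc(OCCCCCCN3CCNCC3c3ncccn3)cc12` is the next compound to be measured in this assay. Compared with compound 2 it carries 2-(pyrimidin-2-yl)piperazin-1-yl in place of 2-(dimethylamino)ethyl on a saturated chain carbon, six bonds along the chain from an oxygen on an aromatic ring. The basic amine at the chain end is kept, while a larger group with an additional ring replaces the dimethylamino terminus.

Among the compounds with values here, with no measured step in hand, the step from compound 2 to compound 3 is expected to stay within the scatter, with a 1.4-fold lower number from compound 2 to compound 3 (0.15 log units; within the scatter) as the estimate, leaning if anything toward a lower number. Compound 3 is therefore expected to give 160 nM, within a range of 35 nM to 750 nM.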

Compound 3, half-maximal inhibitory concentration: 1630 nM
Beside the measured number, compound 3's estimate is 10-fold (1.01 log units) below it; measured number outside the range, above it.
By their numbers in this assay, from the lowest: compounds 1 and 2 (each within the scatter of the next); then compound 3.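

In this assay, going by these compounds alone, 2-(pyrimidin-2-yl)piperazin-1-yl in place of 2-(dimethylamino)ethyl on a saturated chain carbon, six bonds along the chain from an oxygen on an aromatic ring, gives a 7.2-fold higher number from compound 2 to compound 3 (0.86 log units; beyond the scatter) and is the first step to lie beyond the scatter. This position is therefore not indifferent to the group it carries, and here the larger group with two rings goes with the weaker binding result. This single step shows the direction and size of the change but does not explain it, and no supporting measurement bears on its cause.

From the compounds shown here alone, it remains open whether the change follows the piperazine ring, the pyrimidine ring or both together. A plain piperidine or morpholine at the chain end would help to separate these, and the same comparison with a longer chain is also unsettled.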